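A few compounds are considered here, and "the series" means these few. Any claim that something is new, unique, unknown or untested is made for them only; others in the source may bear on it.

Measured in a functional assay on the whole organism (Abdomen, strain ddY) for inhibition, with Mus musculus as the target, with stated times of 30 min and 20 min; on this read-out higher numbers stand for an effect only at larger amounts of compound and lower numbers for an effect already at smaller amounts:

Compound 1 `CCOc1c(NC)cnn(C)c1=O`: 55 mg/kg
Compound 2 `C=CCN(CC=C)c1cnn(C)c(=O)c1OCC`: 82 mg/kg
Compound 3 `CCOc1c(N2CCCCC2)cnn(C)c1=O`: 86 mg/kg

The values of compound 2 and compound 3 both lie within the usual scatter of the value of compound 1, so these numbers place the three level with one another. Compound 4 `CCOc1c(N2CCCC2)cnn(C)c1=O` has not yet been measured. It changes one place on the core of compound 1: pyrrolidin-1-yl in place of methylamino on an aromatic carbon. In words, pyrrolidin-1-yl stands in place of methylamino on an aromatic carbon. Among the compounds with values here, no two measured compounds differ in only one place, so no direct step can guide the expectation. Compound 3, which also carries a ring in this place, gives 86 mg/kg and stays level with compound 1. No change beyond the scatter is therefore expected in this assay. The expected step is a 1.4-fold higher number from compound 1 to compound 4 (0.13 log units; within the scatter) and it points, if anywhere, to a slightly higher number. For compound 4 the estimate is 75 mg/kg, with 42 mg/kg to 135 mg/kg as the expected range.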

Compound 4, dose for half-maximal effect: > 100 mg/kg
Compound 4: no number, only a limit; the forecaster's own chance of this, stated with the estimate: 5%; middle value at least 1.3-fold (0.12 log units) away from the limit.
By their numbers in this assay, from the lowest: compounds 1, 2 and 3 (each within the scatter of the next). At a limit, above all of these: compound 4.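

In this assay, putting pyrrolidin-1-yl in place of methylamino on this aromatic carbon gives the first direct step at this position among the compounds shown: an at least 1.8-fold higher number from compound 1 to compound 4 (0.25 log units; that floor lies within the scatter). Compound 4 stands at a limit of the assay and not at a number, so that step is only a floor, and the real difference could be larger or could still lie within the scatter: the limit of > 100 mg/kg in this assay, at which 1 of the 4 values shown sits. Methylamino carries a hydrogen-bond donor and pyrrolidin-1-yl none, but this single step cannot separate the loss of that donor from the arrival of the ring.

As far as these compounds go, it remains open how ethylamino or dimethylamino would read at this position in this assay. Either group would stand closer to methylamino than pyrrolidin-1-yl does, and neither has a ring.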